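The source may hold more compounds than are shown below. What is called first, only, known or untested is meant among the compounds shown, and "the series" means these compounds.

Measured so far in a functional assay on the whole organism (stomach) for inhibition, with Rattus norvegicus as the target, at a dose of 100 mg/kg by the intraduodenal route; a higher number here means more inhibition at the dose given (going by the name of the read-out), a lower number less inhibition:
compound 1 `N=C(S)CCCn1nc(-c2ccccc2)ccc1=O` with 75.6%
compound 2 `N=C(S)CCCCCn1nc(-c2ccccc2)ccc1=O` with 91.4%

Compound 2 stands highest of the two numbers measured; its nearest neighbour is compound 1, which lies below it by a number 15.8 percentage points higher from compound 1 to compound 2 (beyond the scatter). The unmeasured compound 3 `N=C(S)Cn1nc(-c2ccccc2)ccc1=O` differs from compound 2 by a group of 3 heavy atoms (1 carbon, 1 nitrogen, 1 sulfur; no ring) in place of a group of 7 heavy atoms (5 carbon, 1 nitrogen, 1 sulfur; no ring), on a saturated chain carbon bound to an aromatic nitrogen. Within the data shown here, only one measured step bears on this change, and it runs the other way: going to the larger group gave a number 15.8 percentage points higher from compound 1 to compound 2 (beyond the scatter), a modest step beyond the scatter. Compound 3 moves further toward the smaller group than compound 1 does, so a drop in this assay is expected, and the expected step is a number 33.4 percentage points lower from compound 2 to compound 3 (beyond the scatter), likely larger than the measured step because it passes the level of compound 1 at 75.6% on the way down. Compound 3 is therefore estimated at 58%, with a range from 35% to 80%.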

Compound 3, a percentage reported as inhibition, in the whole organism at one dose (the size of the read-out at that dose, not a potency): 5.5%
Compound 3: the middle estimate sits 52.5 percentage points above what was measured; the measured number lies below the stated range.
By their numbers in this assay, from the lowest: compound 3; then compound 1; then compound 2.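

In this assay the group of 3 heavy atoms on the saturated chain carbon bound to an aromatic nitrogen gives a number 85.9 percentage points lower from compound 2 to compound 3 (beyond the scatter) and also a number 70.1 percentage points lower from compound 1 to compound 3 (beyond the scatter); both steps are large, while the earlier step, a number 15.8 percentage points higher from compound 1 to compound 2 (beyond the scatter), was modest. Across these three compounds, then, the effect of chain length is uneven, and the greater part of the loss lies in the change from the group of 5 heavy atoms to the group of 3 heavy atoms. No measurement here accounts for this uneven loss at this place.

From the compounds shown here alone, whether a longer chain than the group of 7 heavy atoms would raise, hold or lower the inhibition remains open. Going by these compounds, it is also open whether an amine or a carboxylic acid in place of the chain end would retain the inhibition seen with the longer chains.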